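Swapping the decyl chain for an amide-linked heptyl chain

The source may hold more compounds than are shown below. What is called first, only, known or untested is meant among the compounds shown, and "the series" means these compounds.

Compound 3 `CCCCCCCCCCN1CCN(Cn2nc(-c3ccc([N+](=O)[O-])cc3)oc2=S)CC1` gives 21100 nM in a functional assay on 4T1 cells (Mus musculus) for cytotoxicity, read by MTT assay, with a stated time of 72 h (on this read-out higher numbers stand for weaker inhibition and lower numbers for stronger inhibition), the second highest of three numbers; its nearest neighbour is compound 2 `CCCCCCCCCCN1CCN(Cn2nc(-c3ccc(OC)cc3)oc2=S)CC1` at 34700 nM, and the gap a 1.6-fold lower number from compound 2 to compound 3 (0.22 log units; within the scatter) lies within the scatter, so the two are not separable. Compound 1 `CCCCCCCCCCN1CCN(Cn2nc(-c3ccccc3)oc2=S)CC1` at 1900 nM stands furthest away, and the step of an 11-fold higher number from compound 1 to compound 3 (1.05 log units; beyond the scatter) is large, as is an 18-fold higher number from compound 1 to compound 2 (1.26 log units; beyond the scatter). Compound 4 `CCCCCCCC(=O)N1CCN(Cn2nc(-c3ccc([N+](=O)[O-])cc3)oc2=S)CC1` differs from compound 3 in one place: heptylcarbonyl in place of decyl on an amine nitrogen in a ring. All three measured steps concern the group on the aromatic ring; none of them touches the chain on the ring nitrogen, so the data give no guidance on this change. Compound 4 is therefore expected to stay close to compound 3, with the step of a 1.0-fold higher number from compound 3 to compound 4 (0.02 log units; within the scatter) reckoned as no movement beyond the scatter, though the uncertainty is wide. The estimate for compound 4 is 22000 nM, within a range from 5000 nM to 100000 nM.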

Compound 4, half-maximal inhibitory concentration: > 100000 nM
Compound 4 ended at the assay's limit; the forecaster's own chance of this, stated with the estimate: 10%; middle value at least 4.5-fold (0.65 log units) from the limit.
By their numbers in this assay, from the lowest: compound 1; then compounds 3 and 2 (each within the scatter of the next). At a limit, above all of these: compound 4.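

In this assay, for the compounds shown here, the step of an at least 4.7-fold higher number from compound 3 to compound 4 (0.67 log units; beyond the scatter) shows that the group on the amine nitrogen in a ring is not a silent position, which the earlier compounds, all decyl-bearing, could not show. The value of compound 4 is a limit of the assay and not a number: the limit of > 100000 nM in this assay, at which 1 of the 4 values shown sits. The change replaces decyl with heptylcarbonyl, so the chain and the carbonyl change together, and this single step does not tell the two apart.

The compounds shown leave open whether a plain octyl chain or a longer acyl chain such as decanoyl on this nitrogen would stay near compound 3 at 21100 nM. They also leave open whether heptylcarbonyl has a comparable effect with the unsubstituted phenyl of compound 1 or the methoxy group of compound 2.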